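A few compounds are considered here, and "the series" means these few. Any claim that something is new, unique, unknown or untested is made for them only; others in the source may bear on it.

Measured so far:
- Compound 1 `C=C(CC)C(=O)c1ccc(OCC(=O)NCCCN2CCCC2=O)c(Cl)c1Cl`: 13800 nM
- Compound 2 `C=C(CC)C(=O)c1ccc(OCC(=O)Nc2ccc3nc[nH]c3c2)c(Cl)c1Cl`: 3200 nM
- Compound 3 `C=C(CC)C(=O)c1ccc(OCC(=O)Nc2ccc(C#N)cc2)c(Cl)c1Cl`: 7800 nM

All three values come from a functional assay on CLL cells (Homo sapiens) for cytotoxicity, read by MTT assay, with a stated time of 48 h; on this read-out lower numbers stand for an effect already at smaller amounts and higher numbers for an effect only at larger amounts of compound. Compound 1 sits at the upper end of this small set, and compound 3 lies level with it within the scatter (a 1.8-fold lower number from compound 1 to compound 3 (0.25 log units; within the scatter)). Only compound 2 stands clearly apart (a 4.3-fold lower number from compound 1 to compound 2 (0.63 log units; beyond the scatter)).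

The unmeasured compound 4 `C=C(CC)C(=O)c1ccc(OCC(=O)NCC2CCC(C(=O)O)CC2)c(Cl)c1Cl` has 4-carboxycyclohexyl in place of 2-(2-oxopyrrolidin-1-yl)ethyl on a saturated chain carbon bound to an amide-type nitrogen.

The measured steps bear on this change only indirectly, since all of them swap the group on the amide-type nitrogen for an aromatic one. The largest is the step to compound 2 given above, and the other step beyond the scatter is also modest (a 2.4-fold higher number from compound 2 to compound 3 (0.39 log units; beyond the scatter)). Within the data shown here, none of the measured compounds carries 4-carboxycyclohexyl, so the data give no direction for this change. Swaps in this region have so far produced only modest movement in this assay, and no step beyond the scatter is expected here. The expected change is a 1.0-fold higher number from compound 1 to compound 4 (0.01 log units; within the scatter).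

For compound 4 the estimate is 14000 nM, with an expected range of 6000 nM to 35000 nM.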

Compound 4, half-maximal effective concentration: 8000 nM
Compound 4: the middle estimate sits 1.8-fold (0.24 log units) above what was measured; the measured number falls inside the stated range.
By their numbers in this assay, from the lowest: compound 2; then compounds 3, 4 and 1 (each within the scatter of the next).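

Unlike the steps to compound 2 and compound 3, which put an aromatic group on the amide-type nitrogen, this change keeps a saturated chain carbon there, and in this assay it gives a 1.7-fold lower number from compound 1 to compound 4 (0.24 log units; within the scatter). At this place, then, a six-membered non-aromatic ring of carbon only with a carboxylic acid can stand in for 2-(2-oxopyrrolidin-1-yl)ethyl, and the hydrogen-bond donor that enters comes with no step beyond the scatter. No measurement in hand gives a reason for this outcome.

The ring and the end group change together in compound 4, leaving their shares in the step unseparated; a plain cyclohexyl without the carboxylic acid, or the methyl ester of that acid, would pull the two apart. Also open, as far as these compounds go, is whether an amine in place of the carboxylic acid, or a longer chain on the amide-type nitrogen, would move the number beyond the scatter.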